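Clearance notes on a bromo-substituted core with varied nitrogen substituents

The source may report more compounds than this note shows. Statements on the series, on what has been measured and on what is new or still open speak of the compounds shown alone.

Measured compounds:
compound 1 `Clc1ccc(Cn2nnc3c(Br)cccc32)cc1`: 0.6 mL/min/g
compound 2 `Brc1cccc2c1nnn2CC1CCCC1`: 7.9 mL/min/g

In an ADME assay on microsomes from liver (Homo sapiens) for metabolic stability, tested at 2.5 uM (a higher number here means faster removal of the compound, a lower number slower removal), compound 1 gives 0.6 mL/min/g, and in this assay compound 2 gives 7.9 mL/min/g. For the measured compounds named here, compound 2 therefore stands at the higher of the two numbers so far, and its gap to compound 1 lies beyond the scatter. Going by the values given here, no step between measured compounds is available for a pair differing in a single place.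

The next compound is compound 3 `CCCn1nnc2c(Br)cccc21`, to be measured in this assay. Relative to compound 2 the change is ethyl in place of cyclopentyl on a saturated chain carbon bound to an aromatic nitrogen. Compound 1 carries a different group at that same nitrogen and gives the lower number, so some movement toward slower removal seems plausible, though only two points exist and neither maps directly onto this change.

The step from compound 2 to compound 3 is expected to be a 3.2-fold lower number from compound 2 to compound 3 (0.50 log units; beyond the scatter), a moderate drop, possibly within the scatter. Compound 3 is estimated at 2.5 mL/min/g, with a range from 0.8 mL/min/g to 7 mL/min/g.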

Compound 3, intrinsic clearance in a liver preparation (reported as CLH), per the amount of preparation that the assay uses: 4.7 mL/min/g
Compound 3: middle estimate off by 1.9-fold (0.27 log units), on the low side; the measured number falls inside the stated range.
By their numbers in this assay, from the lowest: compound 1; then compounds 3 and 2 (each within the scatter of the next).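

In this assay, for the compounds shown here, the first comparison at this position that differs in one place reads a 1.7-fold lower number from compound 2 to compound 3 (0.23 log units; within the scatter), so ethyl in place of cyclopentyl on a saturated chain carbon bound to an aromatic nitrogen does not separate the two compounds. Losing the five-membered non-aromatic ring of carbon only therefore leaves the read-out within the usual scatter, and at this position neither the ring nor the larger group is shown to matter for clearance in this pair. Nothing measured here explains this result.

Still open, on these data alone, is whether a longer chain, an amine or a carboxylic acid at this position would stay level with compound 2 and compound 3 or come closer to compound 1 at 0.6 mL/min/g in this read-out. As far as these compounds go, the shared core also remains untested with any other bromine replacement.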